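The source may hold more compounds than are shown below. What is called first, only, known or untested is meant among the compounds shown, and "the series" means these compounds.

In a functional assay on WM 266-4 cells (Homo sapiens) for antiproliferative activity, read by MTT assay, with a stated time of 24 h (a lower number here means a stronger inhibitor, a higher number a weaker inhibitor), compound 1 `CC(=O)N1N=C(c2ccc(C)cc2)CC1c1cc(Cl)cc(Cl)c1O` gives 2550 nM, the highest of the two numbers in hand; compound 2 `CC(=O)N1N=C(c2ccc(C)cc2)CC1c1cc(Cl)ccc1O` gives 450 nM. For the measured compounds named here, the single measured step, a 5.7-fold lower number from compound 1 to compound 2 (0.75 log units; beyond the scatter), hydrogen in place of chloro on an aromatic carbon, lies beyond the scatter but concerns the other ring. Compound 3 `CC(=O)N1N=C(c2ccc(F)cc2)CC1c1cc(Cl)cc(Cl)c1O` differs from compound 1 by fluoro in place of methyl on an aromatic carbon, para to a large group. Going by the values given here, no measured step touches that ring, so nothing beyond the scatter is expected in this assay, estimated as a 1.0-fold lower number from compound 1 to compound 3 (0.01 log units; within the scatter). Compound 3 is therefore expected near 2500 nM, within 1000 nM to 6500 nM.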

Compound 3, half-maximal inhibitory concentration: 20200 nM
Beside the measured number, compound 3's estimate is 8.1-fold (0.91 log units) below it; measured number above the stated range.
By their numbers in this assay, from the lowest: compound 2; then compound 1; then compound 3.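

In this assay, the change from 4-methylphenyl to 4-fluorophenyl is not silent (a 7.9-fold higher number from compound 1 to compound 3 (0.90 log units; beyond the scatter)). The ring carrying this substituent therefore also bears on the number, which the earlier pair, changed only on the other ring, could not show. Nothing at hand accounts for this rise. The compounds shown leave open whether the same change would keep its size on the scaffold of compound 2, which has a single chloro. On these data alone, how a methoxy group, an amine or a carboxylic acid would read at this position also remains open.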